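The source may report more compounds than this note shows. Statements on the series, on what has been measured and on what is new or still open speak of the compounds shown alone.

Measured in a functional assay on K562 cells (Homo sapiens) for antiproliferative activity, read by MTT assay, with a stated time of 48 h; on this read-out higher numbers stand for weaker inhibition and lower numbers for stronger inhibition:
compound 1 `COc1ccc(-c2ccc3c(c2)C(=O)C(=O)N3Cc2ccc(F)cc2)cc1` gives 560 nM;
compound 2 `COc1ccc(-c2ccc3c(c2)C(=O)C(=O)N3Cc2ccc(Cl)cc2)cc1` gives 350 nM;
compound 3 `COc1ccc(CN2C(=O)C(=O)c3cc(-c4ccc(F)cc4)ccc32)cc1` gives 240 nM.

Compound 1 and compound 2 differ by one change, (chloro in place of fluoro on an aromatic carbon), and that change brought a 1.6-fold lower number from compound 1 to compound 2 (0.20 log units; within the scatter). Compound 3 has the same atoms as compound 1 joined differently; the difference between the two cores is not broken down here. The unmeasured compound 4 `COc1ccc(CN2C(=O)C(=O)c3cc(-c4ccc(Cl)cc4)ccc32)cc1` stands to compound 3 as compound 2 stands to compound 1: chloro in place of fluoro on an aromatic carbon. The place is described in the same words, so it is the same change, though cut one bond further out the earlier one also reads 4-fluorobenzyl to 4-chlorobenzyl. Compound 3 sits lowest of the three, yet its gap to compound 2 lies within the scatter. Compound 4 is expected to repeat the earlier step, a 1.6-fold lower number from compound 3 to compound 4 (0.20 log units; within the scatter), because in this assay compound 3 gives 240 nM and the change earlier brought a 1.6-fold lower number from compound 1 to compound 2 (0.20 log units; within the scatter). The estimate for compound 4 is 150 nM, between 70 nM and 330 nM.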

Compound 4, half-maximal inhibitory concentration: 230 nM
Compound 4: the middle estimate sits 1.5-fold (0.19 log units) below what was measured; the range from low to high includes it.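

In this assay, chloro in place of fluoro on an aromatic carbon gave a 1.0-fold lower number from compound 3 to compound 4 (0.02 log units; within the scatter), so this core shows no effect of the change that stands clear of the scatter. Set beside the earlier step, the two cores do not part on this change: the same change on two cores in this assay, a 1.6-fold lower number (0.20 log units; within the scatter) from compound 1 to compound 2 and a 1.0-fold lower number (0.02 log units; within the scatter) from compound 3 to compound 4, 1.5-fold (0.19 log units) apart, within the scatter of two such steps. This shows that the change carried across the two cores without a difference that can be told apart, but it does not show that the change does anything on either core, and two pairs make no rule for the series.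

The compounds shown leave open what bromo, a nitrile or an amine would do in place of fluoro and chloro. Also open, as far as these compounds go, is what a carboxylic acid in place of methoxy would do.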